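Benzyl for Allyl on an Inactive Series

A few compounds are considered here, and "the series" means these few. Any claim that something is new, unique, unknown or untested is made for them only; others in the source may bear on it.

Of the compounds shown here, three have so far been tested in a functional assay on RAW264.7 cells (Mus musculus) for inhibition, read by microscopy and resazurin assay, with a stated time of 72 h; on this read-out higher numbers stand for weaker inhibition and lower numbers for stronger inhibition. Compound 1 `C=CCONC(=O)CN1C(=O)S/C(=C\c2cccc(C(=O)N[C@@H](CC(C)C)C(=O)OC)c2)C1=O` carries an allyloxy amide on a chain attached to the shared core. In this assay compound 1 gives only a limit of the measurement, > 128000 nM. Compound 2 `COC(=O)[C@H](CC(C)C)NC(=O)c1cccc(/C=C2\SC(=O)N(CC(=O)NOCc3ccccc3)C2=O)c1` differs from compound 1 by phenyl in place of vinyl on a saturated chain carbon bound to an oxygen on an unsaturated carbon. Compound 2 likewise reaches only a limit in this assay, > 128000 nM. The step that the two limits leave unreadable from compound 1 to compound 2 therefore cannot be sized, because the limit of > 128000 nM in this assay, at which 3 of the 3 values shown sit, covers both of its ends.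

Compound 3 `C=CCONC(=O)CN1C(=O)S/C(=C\c2ccc(C(=O)N[C@H](C(=O)OC)C(C)C)cc2)C1=O` is built on a core of its own; the difference between the core of compound 3 and the core of compound 1 is not broken down here. In this assay compound 3 also gives only a limit, > 128000 nM.

Compound 4 `COC(=O)[C@@H](NC(=O)c1ccc(/C=C2\SC(=O)N(CC(=O)NOCc3ccccc3)C2=O)cc1)C(C)C` has not yet been measured. Among the compounds with values here, it differs from compound 3 by phenyl in place of vinyl on a saturated chain carbon bound to an oxygen on an unsaturated carbon, and this is the same change as the one from compound 1 to compound 2, made at the same place. The earlier change left an unreadable step, a step that the two limits leave unreadable from compound 1 to compound 2, so nothing suggests that swapping a vinyl for a phenyl on this chain moves the read-out. The step from compound 3 to compound 4 is expected to be a number no higher from compound 3 to compound 4 (the limit leaves the size open), that is, essentially no change. Compound 4 is accordingly expected to give 128000 nM in this assay, most likely reported as a limit rather than a number.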

Compound 4, half-maximal inhibitory concentration: > 128000 nM
Compound 4: no number, only a limit (the forecaster's own chance of this, stated with the estimate: 85%); the middle value lies on the limit itself.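

In this assay compound 4 gives > 128000 nM as a limit and not a number. No size can be read for the swap of allyloxy to benzyloxy from compound 3 to compound 4, because both ends rest on the same limit: the limit of > 128000 nM in this assay, at which 4 of the 4 values shown sit. The compounds shown leave open what this swap does to the read-out, and which change to these structures would yield a measurable value.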